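From Bromo to 4-Fluorophenyl on the Shared Core

The source may hold more compounds than are shown below. What is called first, only, known or untested is meant among the compounds shown, and "the series" means these compounds.

Going by the values given here, in a functional assay on MIA PaCa-2 cells (Homo sapiens) for antiproliferative activity, read by MTT assay, with a stated time of 72 h (on this read-out higher numbers stand for weaker inhibition and lower numbers for stronger inhibition), compound 1 `O=C(Nc1ccccn1)c1cc(=O)[nH]c2cc(Br)ccc12` gives 21300 nM, and compound 2 `O=C(Nc1cccc(F)c1)c1cc(=O)[nH]c2cc(Br)ccc12` gives 7500 nM, the lower of the two numbers measured so far. Placing 3-fluorophenyl instead of pyridin-2-yl on the amide-type nitrogen accounts for a 2.8-fold lower number from compound 1 to compound 2 (0.45 log units; beyond the scatter).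

Compound 3 `O=C(Nc1cccc(F)c1)c1cc(=O)[nH]c2cc(-c3ccc(F)cc3)ccc12` keeps the 3-fluorophenyl group of compound 2 but has 4-fluorophenyl in place of bromo on an aromatic carbon. Among the compounds with values here, both measured compounds carry the bromo, so no measured step covers this change directly. Within the data shown here, the only measured step, a 2.8-fold lower number from compound 1 to compound 2 (0.45 log units; beyond the scatter), lies elsewhere on the molecule and serves only as a rough gauge of size. On that slim basis, a modest step toward a lower number is expected in this assay, although the direction is uncertain and a result within the scatter would not be surprising. The expected change is a 1.9-fold lower number from compound 2 to compound 3 (0.27 log units; within the scatter). Compound 3 is estimated at 4000 nM, with an expected range from 1200 nM to 13000 nM.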

Compound 3, half-maximal inhibitory concentration: 19300 nM
The estimate for compound 3 lay 4.8-fold (0.68 log units) below the measured number; measured number outside the range, above it.
By their numbers in this assay, from the lowest: compound 2; then compounds 3 and 1 (each within the scatter of the next).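

In this assay, 4-fluorophenyl in place of bromo gives a 2.6-fold higher number from compound 2 to compound 3 (0.41 log units; beyond the scatter), which shows that this aromatic carbon of the shared core, bromo in both earlier compounds, responds to substitution. With the 3-fluorophenyl group held fixed, the change adds a six-membered aromatic ring of carbon only and brings no hydrogen-bond donors, no hydrogen-bond acceptors and no net charge, yet bromo is the better of the two groups at this carbon on this read-out. Nothing available here accounts for the weaker inhibition, so the step records a direction and a size but no cause.

From the compounds shown here alone, it remains open whether the weaker inhibition belongs to 4-fluorophenyl in particular or extends to other groups at this carbon, such as an unsubstituted phenyl, a methoxy group or an amine. Going by these compounds, it is also open whether the step would keep its direction and size with the pyridin-2-yl group of compound 1 on the amide-type nitrogen in place of 3-fluorophenyl.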